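A Step Hidden Behind Assay Limits

The compounds below may be only part of what the source reports. "The series", "measured", "known", "first", "only" and "open" are said of these compounds alone.

In a functional assay on A-375 cells (Homo sapiens) for cytotoxicity, read by CCK-8 assay, with a stated time of 16 h (on this read-out lower numbers stand for stronger inhibition and higher numbers for weaker inhibition), compound 3 (`COc1ccc2c(c1)CCc1c(-c3ccccc3)c3n(c1-2)[B-](F)(F)[N+]1=C(c2ccc(OCC(=O)O)cc2)C(I)=C(c2ccccc2)C1=N3`) reads > 50000 nM, which is a limit and not a number. Compound 1 (`COc1ccc(C2=[N+]3C(=Nc4c(-c5ccccc5)c5c(n4[B-]3(F)F)-c3ccc(OCC(=O)O)cc3CC5)C(c3ccccc3)=C2I)cc1`) reads > 50000 nM, the same limit, as the limit of > 50000 nM in this assay, at which 2 of the 3 values shown sit, records.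

Compound 4 (`COc1ccc2c(c1)CCc1c(-c3ccccc3)c3n(c1-2)[B-](F)(F)[N+]1=C(c2ccc(OCC(=O)N[C@@H](CC(=O)O)C(=O)O)cc2)C(I)=C(c2ccccc2)C1=N3`) differs from compound 3 by one change: (1,2-dicarboxyethyl)amino in place of hydroxy on a carbonyl carbon. In words, (1,2-dicarboxyethyl)amino stands in place of hydroxy on a carbonyl carbon.

The same change links compound 1 to compound 2 (`COc1ccc(C2=[N+]3C(=Nc4c(-c5ccccc5)c5c(n4[B-]3(F)F)-c3ccc(OCC(=O)N[C@@H](CC(=O)O)C(=O)O)cc3CC5)C(c3ccccc3)=C2I)cc1`). Compound 2 reads > 250000 nM, also a limit. Among the compounds with values here, the only measured comparison is therefore a step that the two limits leave unreadable from compound 1 to compound 2, and it offers no size to carry over.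

Going by compound 2 at > 250000 nM, no gain in inhibition is expected, and the reading will most likely be another limit. The expected change is a step that the limit leaves unreadable from compound 3 to compound 4, a rough expectation with weaker inhibition as the only direction suggested. For compound 4 the estimated value is 250000 nM, with an expected range of 60000 nM to 1000000 nM.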

Compound 4, half-maximal inhibitory concentration in the A-375 assay: > 250000 nM
Compound 4: only a limit was reported; the forecaster's own chance of this, stated with the estimate: 90%; the middle value lies on the limit itself.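

In the A-375 assay compound 3 gives > 50000 nM as a limit and not a number. In the A-375 assay compound 4 gives > 250000 nM as a limit and not a number. Within the data shown here, no step between them can therefore be read. How strongly any compound shown inhibits in the A-375 assay stays open, as does whether swapping hydroxy for (1,2-dicarboxyethyl)amino alters that inhibition at all. In a physicochemical assay for lipophilicity (a lower number here means a more polar compound, a higher number a more lipophilic compound), compound 3 gives 0.92 and compound 4 gives -0.73 as measured numbers.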